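A few compounds are considered here, and "the series" means these few. Any claim that something is new, unique, unknown or untested is made for them only; others in the source may bear on it.

Measured in a functional assay on DU-145 cells (Homo sapiens) for inhibition, read by trypan blue exclusion, with a stated time of 96 h; a lower number here means a stronger inhibitor of growth, a higher number a weaker inhibitor of growth:
- compound 1 `O=C(O)c1ccc(C(=O)/C(=C\c2ccc(F)c([N+](=O)[O-])c2)SCc2ccc(Cl)cc2Cl)cc1`: 1000 nM
- compound 2 `CN(C)c1ccc(/C=C(/Sc2ccc(Br)cc2)C(=O)c2ccc(Cl)cc2)cc1`: > 100000 nM

The entry for compound 2, > 100000 nM, is a limit of the assay and not a number. Among the compounds with values here, that leaves compound 1, at 1000 nM, with the only actual number.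

Compound 3 `O=C(O)c1ccc(C(=O)/C(=C\c2ccc(F)c([N+](=O)[O-])c2)SCc2ccc(Cl)cc2)cc1` keeps the core of compound 1 and has hydrogen in place of chloro on an aromatic carbon, turning 2,4-dichlorobenzyl into 4-chlorobenzyl: hydrogen in place of chloro on an aromatic carbon. No measured pair sizes such a change in this assay. A small step towards weaker growth inhibition is expected, perhaps none beyond the scatter. The expected step is a 1.5-fold higher number from compound 1 to compound 3 (0.18 log units; within the scatter). For compound 3 the estimated value is 1500 nM, with an expected range of 500 nM to 5000 nM.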

Compound 3, concentration for 50% growth inhibition: 50000 nM
Compound 3: middle estimate off by 33-fold (1.52 log units), on the low side, and the stated range ends below it.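

In this assay, this position is far from silent: on the aromatic carbon ortho to a large group, hydrogen in place of chloro gives a 50-fold higher number from compound 1 to compound 3 (1.70 log units; beyond the scatter). The 4-chlorobenzyl group of compound 3 therefore does not by itself retain the growth inhibition seen with the 2,4-dichlorobenzyl group. Compound 2 differs in more than one place and gives a limit, not a number: the limit of > 100000 nM in this assay, at which 1 of the 3 values shown sits.

Open, as far as these compounds go, is whether this step is specific to chloro: fluoro, methyl or methoxy on the same carbon would separate chlorine from any other group there. Also open, from the compounds shown here alone, is whether the step holds without the carboxylic acid.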